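This account rests on a few compounds, and the source may have more. Where it says the series, first, only, none or still open, it means among the compounds named here.

Of the compounds shown here, three built on one shared core have been tested in an assay on CHO cells for displacement of a labelled ligand from adenosine receptor A3 (Homo sapiens), tested at 1 uM; on this read-out higher numbers stand for more inhibition at the one concentration tested (going by the name of the read-out) and lower numbers for less inhibition. Compound 1 `O=C(Nc1ccccc1Cl)Nc1nn(-c2ccccc2)c(=O)c2ccccc12` gives 49% there. Compound 2 `COc1ccc(C(=O)Nc2nn(-c3ccccc3)c(=O)c3ccccc23)cc1`, in this assay, gives 10%; it therefore stands second highest of the three, beyond the scatter below compound 1 and within the scatter of compound 3. Going by the values given here, compound 3 `CC(=O)N(C(C)=O)c1nn(-c2ccccc2)c(=O)c2ccccc12` gives 0% in this assay, and since no step between compound 2 and compound 3 has been worked out, the two values are simply noted side by side.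

Among the compounds with values here, the one step computed so far, a number 39 percentage points lower from compound 1 to compound 2 (beyond the scatter), bears directly on the move toward compound 4 `Cc1ccc(NC(=O)Nc2nn(-c3ccccc3)c(=O)c3ccccc23)cc1`. That change is (4-methylphenyl)amino in place of 4-methoxyphenyl on a carbonyl carbon. It brings back onto the carbonyl carbon an amino-linked aromatic ring of the same kind that compound 1 carries, so the large fall seen from compound 1 to compound 2 is expected to be reversed in good part. Compound 4 is therefore estimated at 38%, within a range of 12% to 60%, which means an expected step of a number 28 percentage points higher from compound 2 to compound 4 (beyond the scatter).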

Compound 4, a percentage reported as inhibition, at one concentration (the size of the read-out at that concentration, not a potency): 45%
The estimate for compound 4 lay 7 percentage points below the measured number; measured number inside the range.
By their numbers in this assay, from the lowest: compounds 3 and 2 (each within the scatter of the next); then compounds 4 and 1 (each within the scatter of the next).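

In this assay, putting (4-methylphenyl)amino in place of 4-methoxyphenyl on a carbonyl carbon gives a number 35 percentage points higher from compound 2 to compound 4 (beyond the scatter), so the high number of compound 1 is not unique to that compound: it goes with an amino-linked aromatic ring at this carbonyl carbon. Changing the ring on the amide-type nitrogen, with 4-methylphenyl in place of 2-chlorophenyl, gives a number 4 percentage points lower from compound 1 to compound 4 (within the scatter), so these two rings cannot be told apart here. No measurement shown bears on the reason for either step.

From the compounds shown here alone, what a methylene or an ether oxygen would give in place of the amino link stays open, as does the effect of a cyclohexyl ring in place of the aromatic ring. Nor can the pair of 2-chlorophenyl and 4-methylphenyl separate the substituent from where it sits on the ring.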